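Trimming the Amide Side Chain Toward Compound 3

The source may hold more compounds than are shown below. What is called first, only, known or untested is meant among the compounds shown, and "the series" means these compounds.

In a functional assay on the whole organism with Mus musculus as the target, with a stated time of 90 min, at a dose of 25 umol/kg by the oral route; a lower number here means a weaker effect, a higher number a stronger effect of the compound at the dose given:
compound 1 `C[C@H](NC(=O)CN(c1nc(Cl)nc2c1ncn2C1CCCCO1)C1CC1)C(=O)OCc1ccccc1` gives 32.1%
compound 2 `O=C(CN(c1nc(Cl)nc2c1ncn2C1CCCCO1)C1CC1)N[C@@H](CC(=O)OCc1ccccc1)C(=O)OCc1ccccc1` gives 25.1%

Compound 2 stands lowest of these two numbers, though its gap to compound 1 is within the scatter. Compound 3 `O=C(CN(c1nc(Cl)nc2c1ncn2C1CCCCO1)C1CC1)NCC(=O)OCc1ccccc1` differs from compound 2 by hydrogen in place of (benzyloxycarbonyl)methyl on a saturated chain carbon bound to an amide-type nitrogen and a carbonyl carbon. Among the compounds with values here, the only measured step sits on the same saturated chain: adding a benzyloxycarbonyl group gave a number 7 percentage points lower from compound 1 to compound 2 (within the scatter), a change within the scatter. Removing the (benzyloxycarbonyl)methyl group is therefore expected to give a number 2.9 percentage points higher from compound 2 to compound 3 (within the scatter), no move beyond the scatter. Compound 3 is estimated at 28%, with a range from 12% to 44%.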

Compound 3, a percentage reported as activity, at one dose (the size of the read-out at that dose, not a potency): 25.9%
Compound 3: middle estimate off by 2.1 percentage points, on the high side; measured number inside the range.
By their numbers in this assay, from the lowest: compounds 2, 3 and 1 (each within the scatter of the next).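

In this assay, on the saturated chain carbon bound to an amide-type nitrogen and a carbonyl carbon, hydrogen in place of (benzyloxycarbonyl)methyl gives a number 0.8 percentage points higher from compound 2 to compound 3 (within the scatter), and hydrogen in place of methyl gives a number 6.2 percentage points lower from compound 1 to compound 3 (within the scatter). Both steps stay within the scatter, so at this position neither methyl nor (benzyloxycarbonyl)methyl, with its 11 heavy atoms, separates from hydrogen. No supporting data bear on why this is so. On these data alone, whether a carboxylic acid in place of the benzyloxycarbonyl group, or an amine on this carbon, would separate from hydrogen remains open.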